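Swapping a Cyclohexylamide for a Piperazine Amide

A few compounds are considered here, and "the series" means these few. Any claim that something is new, unique, unknown or untested is made for them only; others in the source may bear on it.

Of the compounds shown here, three sharing one core have been tested in a functional assay on the whole organism (strain Wistar) for inhibition, with Rattus norvegicus as the target, read by paw edema, with stated times of 60 min and 3 h, at a dose of 100 mg/kg by the oral route; a higher number here means more inhibition at the dose given (going by the name of the read-out), a lower number less inhibition. Compound 1 `COc1cc2c(cc1OC)C(CC(=O)O)CC2` carries a free acid on the carbonyl carbon and gives 27.5%. Compound 2 `CCCCNC(=O)CC1CCc2cc(OC)c(OC)cc21` has butylamino in place of that hydroxy and gives 27.5%, so no change at the digits printed from compound 1 to compound 2 (within the scatter). Compound 3 `COc1cc2c(cc1OC)C(CC(=O)NC1CCCCC1)CC2` instead carries cyclohexylamino and gives 49.3%, the highest of the three numbers: a number 21.8 percentage points higher from compound 1 to compound 3 (beyond the scatter), and a number 21.8 percentage points higher from compound 2 to compound 3 (beyond the scatter).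

The next compound, compound 4 `COc1cc2c(cc1OC)C(CC(=O)N1CCNCC1)CC2`, changes the same position once more: piperazin-1-yl in place of cyclohexylamino on a carbonyl carbon. Going by the values given here, no measured step covers a piperazin-1-yl group, so the expectation rests on the steps already seen at this carbonyl carbon. The only gain came from cyclohexyl, the very group that now leaves; hydroxy and butylamino sat at the same level as each other. A group that is neither of these is therefore expected to fall back toward the level of compound 1 and compound 2 rather than hold the level of compound 3, though with wide uncertainty.

Compound 4 is thus estimated to give 32% in this assay, within a range from 15% to 50%. The expected change is a number 17.3 percentage points lower from compound 3 to compound 4 (beyond the scatter).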

Compound 4, a percentage reported as inhibition, in the whole organism at one dose (the size of the read-out at that dose, not a potency): 42%
Compound 4: the middle estimate sits 10 percentage points below what was measured, within the range that was stated.
By their numbers in this assay, from the lowest: compounds 1 and 2 (each within the scatter of the next); then compounds 4 and 3 (each within the scatter of the next).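

In this assay, replacing the cyclohexylamino group on the carbonyl carbon with piperazin-1-yl gives a number 7.3 percentage points lower from compound 3 to compound 4 (within the scatter), so the higher level at this position does not depend on a ring of carbon only: a six-membered ring holding hetero atoms cannot be told apart from it here. The same group gives a number 14.5 percentage points higher from compound 2 to compound 4 (beyond the scatter) and a number 14.5 percentage points higher from compound 1 to compound 4 (beyond the scatter), so among these four compounds, the two amides with a six-membered ring on the carbonyl carbon stand apart from the free acid and the butylamino amide, and no compound goes against that split. Nothing available here accounts for this result.

The compounds shown leave open whether the ring itself matters, or whether an open-chain group such as tert-butylamino would reach the same level. They also leave open how far the ring can vary, for example whether morpholin-4-yl, with an oxygen in place of the second ring nitrogen, or 4-methylpiperazin-1-yl, with a methyl on that nitrogen, would stay at the level of compound 3 and compound 4.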